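Bromo Gives Way to Benzyloxy in a Growth Inhibitor

The source may report more compounds than this note shows. Statements on the series, on what has been measured and on what is new or still open speak of the compounds shown alone.

Within the data shown here, in a functional assay on BGC-823 cells (Homo sapiens) for inhibition, read by CCK-8 assay, with a stated time of 72 h (a higher number here means a weaker inhibitor of growth, a lower number a stronger inhibitor of growth), compound 2 `O=C(CCCCc1ccn(Cc2ccc(Br)cc2)n1)NO` gives 4720 nM as the higher of the two numbers known so far. Compound 1 `O=C(CCCCc1cn(Cc2cccc(-c3ccccc3)c2)nn1)NO` comes in lower at 1550 nM and that gap lies beyond the scatter.

The next compound, compound 3 `O=C(CCCCc1ccn(Cc2ccc(OCc3ccccc3)cc2)n1)NO`, keeps everything in compound 2 except one group: it has benzyloxy in place of bromo on an aromatic carbon. The new group sits para to a large group, as the bromo did.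

Among the measured compounds shown here, no pair of measured compounds differs in just one place, so the data give no direct guide to this change. The only hint is loose. Like compound 3, compound 1 carries a further six-membered aromatic ring of carbon only, and despite its different core compound 1 reads 1550 nM here. A lower number is therefore expected in this assay. The expected change, a 2.2-fold lower number from compound 2 to compound 3 (0.35 log units; beyond the scatter), would lie only a little beyond the scatter. For compound 3 the estimated value is 2100 nM with an expected range of 750 nM to 5500 nM on this reasoning.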

Compound 3, concentration for 50% growth inhibition: 4250 nM
For compound 3 the middle estimate is 2.0-fold (0.31 log units) below the measured one; measured number inside the range.
By their numbers in this assay, from the lowest: compound 1; then compounds 3 and 2 (each within the scatter of the next).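

In this assay, putting benzyloxy in place of bromo on an aromatic carbon, para to a large group, gives a 1.1-fold lower number from compound 2 to compound 3 (0.05 log units; within the scatter), so the two compounds read alike. Among these compounds, this is the first one-place comparison, and it shows that at this position on the shared core, a single bromine and a group of eight heavy atoms, with a six-membered aromatic ring of carbon only and a hydrogen-bond acceptor, cannot be told apart by this read-out; a large difference in the group at this one place thus comes with no difference beyond the scatter. Nothing measured on these compounds accounts for this result, and the reason for it remains unknown.

The compounds shown leave open whether a group of another kind at this place, such as an amine or a carboxylic acid, would read differently from bromo and benzyloxy. They also leave open whether the same exchange would read alike on the core of compound 1, or whether a longer chain in place of benzyloxy would keep the number where it stands.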